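Methoxy Added to a Compound Known Only as a Limit

The source may hold more compounds than are shown below. What is called first, only, known or untested is meant among the compounds shown, and "the series" means these compounds.

Three measured compounds share one core. Compound 1 `O=C1NC(=O)/C(=C/C2=Cc3ccccc3OC2)S1` carries a hydrogen on its ring nitrogen, and in a functional assay on MOLT-4 cells (Homo sapiens) for antiproliferative activity, read by MTT assay, with a stated time of 72 h (a lower number here means a stronger inhibitor, a higher number a weaker inhibitor), compound 1 gives 101000 nM. Compound 2 `CN1C(=O)S/C(=C\C2=Cc3ccccc3OC2)C1=O` carries a methyl on that nitrogen; in this assay compound 2 gives > 100000 nM, which is a limit of the assay and not a number. Compound 3 `CCN1C(=O)S/C(=C\C2=Cc3ccccc3OC2)C1=O` carries an ethyl there; in this assay compound 3 gives > 200000 nM, also a limit and not a number. Compound 3 therefore stands only as a limit, and one further value in the set is a limit as well.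

Among the measured steps, a step that the limit leaves unreadable from compound 1 to compound 2 cannot be read because of the limit of > 100000 nM in this assay, at which 1 of the 3 values shown sits. The step of an at least 1.9-fold higher number from compound 1 to compound 3 (0.29 log units; that floor lies within the scatter) has a floor that lies within the scatter. The step that the two limits leave unreadable from compound 2 to compound 3 cannot be read because of the limit of > 200000 nM in this assay, at which 1 of the 3 values shown sits.

Compound 4 `CCN1C(=O)S/C(=C\C2=Cc3cccc(OC)c3OC2)C1=O` differs from compound 3 by methoxy in place of hydrogen on an aromatic carbon. Among the compounds with values here, none of the measured steps touches the aromatic ring; all concern the ring nitrogen, so none bears directly on this change. Compound 4 is therefore expected to give about 200000 nM in this assay, within 50000 nM to 600000 nM, most likely reported again as a limit. The step of a number no higher from compound 3 to compound 4 (the limit leaves the size open) is estimated to stay within the scatter.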

Compound 4, half-maximal inhibitory concentration: 13200 nM
The estimate for compound 4 lay 15-fold (1.18 log units) above the measured number; the whole stated range lies above it.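

Within the data shown here, the aromatic ring of the shared core, which none of the earlier compounds changed, turns out to be a place where a single substitution moves the number a long way: in this assay, methoxy in place of hydrogen gives an at least 15-fold lower number from compound 3 to compound 4 (1.18 log units; beyond the scatter). The earlier steps shown here, all on the ring nitrogen, showed nothing of this kind, as two of them cannot be read and the floor of the third lies within the scatter. Compound 3 gives > 200000 nM, which is a limit and not a number, so the new step is known only as a floor and its full size stays open: the limit of > 200000 nM in this assay, at which 1 of the 4 values shown sits.

The compounds shown leave open whether methoxy would bring a similar drop on the core of compound 1 or compound 2, or at another carbon of the aromatic ring. They also leave open whether a hydroxyl, a chlorine or a longer chain such as ethoxy at this same place would give a number like that of compound 4.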